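From compound 3 to compound 4: one group exchanged

This account rests on a few compounds, and the source may have more. Where it says the series, first, only, none or still open, it means among the compounds named here.

Measured in a physicochemical assay for solubility, in phosphate buffer, at pH 7.4; on this read-out higher numbers stand for higher solubility and lower numbers for lower solubility:
Compound 1 `CC(=O)N[C@@H]1CCC[C@H](C(=O)Nc2cc(-c3cnn4c3CCCC4)ccn2)C1` gives 730000 nM
Compound 2 `CC(=O)N[C@@H]1CCC[C@H](C(=O)Nc2cc(-c3cnn4c3CCCC4)c(F)cn2)C1` gives > 1000000 nM (a limit of the assay, not a number)
Compound 3 `CC(=O)N[C@@H]1CCC[C@H](C(=O)Nc2cc(-c3cnn(C)c3C)c(Cl)cn2)C1` gives 960000 nM

Among the compounds with values here, compound 3, at 960000 nM, lies within the scatter of compound 1, the only other exact number. Compound 4 `CC(=O)N[C@@H]1CCC[C@H](C(=O)Nc2cc(-c3cnc4ccccn34)c(Cl)cn2)C1` differs from compound 3 by one exchange: a group of 9 heavy atoms (7 carbon, 2 nitrogen; one five-membered aromatic ring with 2 hetero atoms, one six-membered aromatic ring with 1 hetero atom) in place of a group of 7 heavy atoms (5 carbon, 2 nitrogen; one five-membered aromatic ring with 2 hetero atoms), on an aromatic carbon. The 1,5-dimethyl-1H-pyrazol-4-yl group leaves an aromatic carbon ortho to a chloro group and opposite the ring nitrogen, and the larger group enters there.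

Within the data shown here, no measured step makes this exchange. Among the measured compounds shown here, the only step available is an at least 1.3-fold higher number from compound 1 to compound 2 (0.13 log units; that floor lies within the scatter), which places fluoro in place of hydrogen on an aromatic carbon and ends at the limit of > 1000000 nM in this assay, at which 1 of the 3 values shown sits. It gives no size for the present change, so only a modest move to a lower number is expected in this assay, and a result within the scatter would not surprise. The step expected is a 2.4-fold lower number from compound 3 to compound 4 (0.38 log units; beyond the scatter). Compound 4 is estimated at 400000 nM, with an expected range from 120000 nM to 1000000 nM.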

Compound 4, solubility: 120000 nM
Compound 4: middle estimate off by 3.3-fold (0.52 log units), on the high side; the measured number falls inside the stated range.
By their numbers in this assay, from the lowest: compound 4; then compounds 1 and 3 (each within the scatter of the next). At a limit, above all of these: compound 2.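

In this assay, placing the larger group, with its five-membered and six-membered aromatic rings, on the aromatic carbon ortho to a chloro group instead of 1,5-dimethyl-1H-pyrazol-4-yl gives an 8.0-fold lower number from compound 3 to compound 4 (0.90 log units; beyond the scatter). Within the data shown here, this shows that the number can move beyond the scatter with the group at this position, which the only earlier step, an at least 1.3-fold higher number from compound 1 to compound 2 (0.13 log units; that floor lies within the scatter), could not show. The two groups have the same counts of hydrogen-bond donors and acceptors and the same net charge, so the step comes without a change in those counts, and nothing shown gives a cause for it.

The compounds shown leave open whether the step follows the second aromatic ring or simply the larger count of heavy atoms, which a single-ring group of similar size, such as a phenyl ring, could begin to separate. They also leave open whether the same exchange gives a step of similar size with fluoro or hydrogen in place of the chloro group, and how a morpholine or a dimethylamino group on the entering rings would move the number.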